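The source may hold more compounds than are shown below. What is called first, only, known or untested is meant among the compounds shown, and "the series" means these compounds.

Measured compounds in the series:

Compound 1 `C[C@H](NC(=O)c1nnn(Cc2ccc(F)cc2)c1C(F)(F)F)c1ccc(C(=O)O)cc1` — in a functional assay on CHO cells for antagonist activity at prostaglandin E2 receptor EP4 subtype (Homo sapiens), read by calcium flux, with a stated time of 15 min (a lower number here means a stronger inhibitor, a higher number a weaker inhibitor), compound 1 gives only a limit, > 10000 nM.
Compound 2 `Cc1nnn(Cc2ccc(C(F)(F)F)cc2)c1C(=O)N[C@@H](C)c1ccc(C(=O)O)cc1` — in this assay compound 2 likewise gives only a limit, > 10000 nM.
Compound 3 `CCCc1nnn(Cc2ccc(C(F)(F)F)cc2)c1C(=O)N[C@@H](C)c1ccc(C(=O)O)cc1` — in this assay compound 3 gives 68.8 nM.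

Among the compounds with values here, compound 3 thus stands as the only numerical value shown; the two others sit at the limit of > 10000 nM in this assay, at which 2 of the 3 values shown sit. Within the data shown here, the single measured step, an at least 140-fold lower number from compound 2 to compound 3 (2.16 log units; beyond the scatter), runs from a limit to a number and is therefore known only as a lower bound on its size.

Compound 4 `C[C@H](NC(=O)c1c(C2CCCC2)nnn1Cc1ccc(C(F)(F)F)cc1)c1ccc(C(=O)O)cc1` differs from compound 3 by cyclopentyl in place of propyl on an aromatic carbon. Among the measured compounds shown here, the one step that bears on this position is the step from compound 2 to compound 3, where lengthening the chain on the shared core gave the large gain just noted. Going from propyl to cyclopentyl continues to enlarge the same position, so a number in the same region as compound 3, or somewhat lower, is expected rather than a return toward the limit. Compound 4 is therefore estimated at 40 nM, with a range of 10 nM to 200 nM; this means an expected step of a 1.7-fold lower number from compound 3 to compound 4 (0.24 log units; within the scatter).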

Compound 4, half-maximal inhibitory concentration: 65.1 nM
Estimate against measurement, compound 4: 1.6-fold (0.21 log units) below; measured number inside the range.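

In this assay the new result gives a 1.1-fold lower number from compound 3 to compound 4 (0.02 log units; within the scatter), so on this aromatic carbon cyclopentyl serves as well as propyl, and the activity seen with propyl does not depend on an open chain. Measured against methyl at the same place, the ring gives an at least 150-fold lower number from compound 2 to compound 4 (2.18 log units; beyond the scatter), a second large step that matches the one seen with propyl. Both steps from compound 2 are lower bounds on size, as its entry is a limit and not a number: the limit of > 10000 nM in this assay, at which 2 of the 4 values shown sit.

Still open, on these data alone, is where the size of this group stops being accepted, for instance with a phenyl ring, a cyclohexyl ring or a longer chain. Also open, as far as these compounds go, is whether the position accepts a group carrying an amine or a hydroxyl.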